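Aryl variation on the piperazine nitrogen of the oxime series

This account rests on a few compounds, and the source may have more. Where it says the series, first, only, none or still open, it means among the compounds named here.

Measured so far:
compound 1 `CCO/N=C(\CCN1CCN(c2ccccc2C#N)CC1)c1ccccc1` — 48.7 nM in a functional assay on HEK293 cells with D(4) dopamine receptor (Homo sapiens) as the target, read by FLIPR; on this read-out higher numbers stand for an effect only at larger amounts of compound and lower numbers for an effect already at smaller amounts
compound 2 `CCO/N=C(\CCN1CCN(c2cccc(OC)c2)CC1)c1ccccc1` — 2680 nM in this assay

Compound 2 stands at the highest of the two numbers in this assay; its nearest neighbour is compound 1, and the step of a 55-fold higher number from compound 1 to compound 2 (1.74 log units; beyond the scatter) is large. The next compound, compound 3 `CCO/N=C(\CCN1CCN(c2ncccc2C#N)CC1)c1ccccc1`, is not yet measured. It differs from compound 2 as 3-cyanopyridin-2-yl in place of 3-methoxyphenyl on an amine nitrogen in a ring, so a nitrile returns to the ring on the amine nitrogen and a ring nitrogen is added. For the measured compounds named here, the only step that bears on this is a 55-fold higher number from compound 1 to compound 2 (1.74 log units; beyond the scatter), which went against compound 2 when the nitrile-bearing ring was exchanged for the 3-methoxyphenyl; nothing measured here tells how the ring nitrogen on its own behaves. Compound 3 is therefore expected to move back toward compound 1, with a 27-fold lower number from compound 2 to compound 3 (1.43 log units; beyond the scatter) as a large step downward. The estimate for compound 3 in this assay is 100 nM, with a range from 30 nM to 400 nM.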

Compound 3, half-maximal effective concentration: 139 nM
Compound 3: middle estimate off by 1.4-fold (0.14 log units), on the low side; measured number inside the range.
By their numbers in this assay, from the lowest: compound 1; then compound 3; then compound 2.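

The change shows a 19-fold lower number from compound 2 to compound 3 (1.29 log units; beyond the scatter) in this assay and closes most of the gap opened by the 3-methoxyphenyl, so a nitrile-bearing ring on this amine nitrogen in a ring again gives a low number, now with two such rings against one without. The recovery is incomplete, with a 2.9-fold higher number from compound 1 to compound 3 (0.46 log units; beyond the scatter) as a modest step beyond the scatter, so 3-cyanopyridin-2-yl does not simply stand in for 2-cyanophenyl at this position. The ring nitrogen, which earlier compounds could not address, is what separates these two groups. Nothing available accounts for either step.

Still open, going by these compounds, is where a plain pyridin-2-yl or a 2-methoxyphenyl would fall on this nitrogen. That leaves the nitrile and its place on the ring unseparated as the source of the difference from compound 2.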